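Nitro in Place of Amino: Expectation for Compound 4

The source may hold more compounds than are shown below. What is called first, only, known or untested is meant among the compounds shown, and "the series" means these compounds.

Compound 3 `COc1ccc(/C(F)=C\c2cc(OC)c(OC)c(OC)c2)cc1N` and compound 2 `COc1ccc(/C(F)=C\c2cc(OC)c(OC)c(OC)c2)cc1[N+](=O)[O-]` share one core. In a functional assay on HT-29 cells (Homo sapiens) for cytotoxicity, read by sulforhodamine B assay, with a stated time of 72 h (on this read-out higher numbers stand for weaker inhibition and lower numbers for stronger inhibition), compound 3 gives 5 nM and compound 2 gives 202 nM. The change between them is nitro in place of amino on an aromatic carbon, and it made a step of a 40-fold higher number from compound 3 to compound 2 (1.61 log units; beyond the scatter). Compound 1 `COc1ccc(/C=C(/F)c2cc(OC)c(OC)c(OC)c2)cc1N` has the same atoms as compound 3, joined differently; the difference between the two cores is not broken down here. In this assay compound 1 gives 2.9 nM, which lies within the scatter of compound 3. Compound 4 `COc1ccc(/C=C(/F)c2cc(OC)c(OC)c(OC)c2)cc1[N+](=O)[O-]` carries the same change on the core of compound 1, namely (nitro in place of amino on an aromatic carbon), at the same place. Because the earlier step was a 40-fold higher number from compound 3 to compound 2 (1.61 log units; beyond the scatter), compound 4 is expected to show a step of a 41-fold higher number from compound 1 to compound 4 (1.62 log units; beyond the scatter). Compound 4 is therefore estimated at 120 nM, expected between 40 nM and 400 nM.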

Compound 4, half-maximal inhibitory concentration: 32 nM
For compound 4 the middle estimate is 3.8-fold (0.57 log units) above the measured one; measured number below the stated range.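

Set on the other core, nitro in place of amino again gave a higher number in this assay, with an 11-fold higher number from compound 1 to compound 4 (1.04 log units; beyond the scatter), so the direction of the change carried over. Its size did not carry over unchanged: the same change on two cores in this assay, a 40-fold higher number (1.61 log units; beyond the scatter) from compound 3 to compound 2 and an 11-fold higher number (1.04 log units; beyond the scatter) from compound 1 to compound 4, 3.7-fold (0.56 log units) apart, beyond the scatter of two such steps These two pairs show that the step in this series depends on the core to a measurable degree, but they do not show why the steps differ or how the change would behave on any further core.

The compounds shown leave open how a hydroxyl, an acetamide or a nitrile would behave on this aromatic carbon. They also leave open whether the steps for such groups would differ between the two cores.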